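The source may hold more compounds than are shown below. What is called first, only, known or untested is meant among the compounds shown, and "the series" means these compounds.

Measured so far:
Compound 1 `O=C1/C(=C/c2cccnc2)CN(S(=O)(=O)c2ccc(F)cc2)C/C1=C\c1ccccc1F`: 15600 nM
Compound 2 `O=C1/C(=C/c2cccnc2)CN(S(=O)(=O)c2ccc(Br)cc2)C/C1=C\c1ccccc1F`: 8700 nM
Not yet measured:
Compound 3 `N#Cc1ccc(S(=O)(=O)N2C/C(=C\c3cccnc3)C(=O)/C(=C/c3ccccc3F)C2)cc1`

Within the data shown here, in a functional assay on HepG2 cells (Homo sapiens) for cytotoxicity, read by MTT assay, with a stated time of 24 h (on this read-out higher numbers stand for weaker inhibition and lower numbers for stronger inhibition), compound 2 gives 8700 nM, which lies within the scatter of compound 1, the only other compound measured. Compound 3 differs from compound 2 at one place, with cyano in place of bromo on an aromatic carbon, para to a large group, so that 4-bromophenyl becomes 4-cyanophenyl (cyano in place of bromo on an aromatic carbon). Among the measured compounds shown here, the only measured step that bears on this change is a 1.8-fold lower number from compound 1 to compound 2 (0.25 log units; within the scatter), which also exchanges the group on that aromatic carbon and stays within the scatter. For the measured compounds named here, no compound with a cyano group has been measured yet. No step beyond the scatter is therefore expected in this assay. The expected step is a 1.3-fold higher number from compound 2 to compound 3 (0.10 log units; within the scatter). For compound 3 the estimated value is 11000 nM, with an expected range of 5000 nM to 24000 nM.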

Compound 3, half-maximal inhibitory concentration: 6600 nM
Compound 3: the middle estimate sits 1.7-fold (0.22 log units) above what was measured; the measured number falls inside the stated range.
By their numbers in this assay, from the lowest: compounds 3, 2 and 1 (each within the scatter of the next, the first and the last beyond it).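

In this assay, cyano in place of bromo on the aromatic carbon para to a large group gives a 1.3-fold lower number from compound 2 to compound 3 (0.12 log units; within the scatter) and so leaves the two groups indistinguishable. Cyano in place of fluoro at the same carbon gives a 2.4-fold lower number from compound 1 to compound 3 (0.37 log units; beyond the scatter) and is the first exchange at this position to pass beyond the scatter, though only modestly, while bromo remains within the scatter of both others. No measurement shown accounts for this modest step.

On these data alone, what an amine, a carboxylic acid or a methoxy group would do at this carbon remains open, as does the result of leaving this position unsubstituted. As far as these compounds go, it is also open whether the step seen with cyano and fluoro would hold if another part of the shared core were changed.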